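The source may report more compounds than this note shows. Statements on the series, on what has been measured and on what is new or still open speak of the compounds shown alone.

Compound 2 `C=C1C(=O)O[C@@H](c2ccccc2)[C@H]1C` stands second highest of the three numbers gathered so far in a functional assay on BXPC-3 cells (Homo sapiens) for cytotoxicity, read by MTT assay, with a stated time of 72 h, tested at 10 uM; a lower number here means a stronger effect, a higher number a weaker effect of the compound at the concentration tested: compound 2 gives 41%. Its nearest neighbour is compound 3 `C=C1C(=O)O[C@@H](c2ccc(OC)cc2)[C@H]1C`, which in this assay gives 13%, a step of a number 28 percentage points lower from compound 2 to compound 3 (beyond the scatter) brought about by methoxy in place of hydrogen on an aromatic carbon. Furthest away is compound 1 `C=C1C(=O)O[C@@H](C2CCCCC2)[C@H]1c1ccccc1`, which in this assay gives 95%; compound 1 differs from compound 2 in two places, so its two values are only set side by side here.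

Compound 4 `C=C1C(=O)O[C@@H](c2ccccc2)[C@H]1c1ccccc1` arises from compound 2 by phenyl in place of methyl on a saturated ring carbon. Among the measured compounds shown here, no measured step bears directly on this change. For the measured compounds named here, the only compound carrying a phenyl at that place, compound 1, shows a weak effect, but its other change leaves the comparison open. On this thin ground a weakening of the effect is expected, so that the step from compound 2 to compound 4 in this assay is estimated as a number 24 percentage points higher from compound 2 to compound 4 (beyond the scatter). Compound 4 is therefore expected to give about 65% in this assay, in a range from 35% to 95%.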

Compound 4, a percentage reported as activity, at one concentration (the size of the read-out at that concentration, not a potency): 8%
For compound 4 the middle estimate is 57 percentage points above the measured one, and the stated range ends above it.
By their numbers in this assay, from the lowest: compounds 4 and 3 (each within the scatter of the next); then compound 2; then compound 1.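

In this assay, phenyl in place of methyl on a saturated ring carbon gives a number 33 percentage points lower from compound 2 to compound 4 (beyond the scatter), so this place, two ring bonds from the ring oxygen, takes the aromatic ring with a gain in effect rather than a loss. Phenyl at this place therefore does not by itself go with a weak effect: with phenyl in place of cyclohexyl on the other substituted saturated ring carbon, the shift is a number 87 percentage points lower from compound 1 to compound 4 (beyond the scatter), so the group at that second carbon also weighs heavily. Nothing measured here explains either step.

Going by these compounds, it remains open whether methoxy on an aromatic ring of compound 4 would act as it does in the step of a number 28 percentage points lower from compound 2 to compound 3 (beyond the scatter). On these data alone, it is equally open how an amine or a longer chain would behave at the place now held by phenyl.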